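Aryl Substituent Change on a Triazole Nitrogen

The source may hold more compounds than are shown below. What is called first, only, known or untested is meant among the compounds shown, and "the series" means these compounds.

Measured compounds:
Compound 1 `Cc1cccc(-n2nncc2CN2C(=O)C3(C(C#N)=C(N)Oc4c(N)cc5nc6ccccc6nc5c43)c3ccccc32)c1` gives 12300 nM in a functional assay on A549 cells (Homo sapiens) for antiproliferative activity, read by MTT assay, with a stated time of 48 h; on this read-out higher numbers stand for weaker inhibition and lower numbers for stronger inhibition.
Compound 2 `N#CC1=C(N)Oc2c(N)cc3nc4ccccc4nc3c2C12C(=O)N(Cc1cnnn1-c1c(F)cccc1F)c1ccccc12` gives > 50000 nM in this assay, which is a limit of the assay and not a number.

Compound 2 therefore stands at the limit of this assay, (the limit of > 50000 nM in this assay, at which 1 of the 2 values shown sits), and its true value is not known beyond that. Compound 3 `COc1ccc(OC)c(-n2nncc2CN2C(=O)C3(C(C#N)=C(N)Oc4c(N)cc5nc6ccccc6nc5c43)c3ccccc32)c1` differs from compound 2 in one place: 2,5-dimethoxyphenyl in place of 2,6-difluorophenyl on an aromatic nitrogen. Among the measured compounds shown here, one measured step bears on this position: an at least 4.0-fold higher number from compound 1 to compound 2 (0.60 log units; beyond the scatter). That step shows that exchanging the aryl group on the aromatic nitrogen moves the read-out in this assay by a modest amount. The 2,5-dimethoxyphenyl of compound 3 is neither the 3-methylphenyl of compound 1 nor the 2,6-difluorophenyl of compound 2, so the direction of the new step cannot be read from that single measured step. With compound 2 at a limit, the step to compound 3 is expected either to bring the number back toward the region seen for compound 1 or to leave it at the limit. Compound 3 is expected to give 25000 nM in this assay, within 8000 nM to 80000 nM. The estimated step is an at least 2.0-fold lower number from compound 2 to compound 3 (0.30 log units; that floor lies within the scatter).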

Compound 3, half-maximal inhibitory concentration: 28100 nM
Estimate against measurement, compound 3: 1.1-fold (0.05 log units) below, and the stated range covers the measured number.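

Compound 3 gives a readable number in this assay with a 2,5-dimethoxyphenyl on the aromatic nitrogen, so a second aryl group at this position now has a measured value, and the change from the 3-methylphenyl gives a 2.3-fold higher number from compound 1 to compound 3 (0.36 log units; beyond the scatter). With steps beyond the scatter to both other compounds, compound 1 remains the strongest of the three, although the gap to compound 3 is only modest. The change from the 2,6-difluorophenyl gives an at least 1.7-fold lower number from compound 2 to compound 3 (0.25 log units; that floor lies within the scatter), and since only the floor of that step is known and it lies within the scatter, no order can be set between these two aryl groups.

Compound 2 stands at a limit and not at a number: the limit of > 50000 nM in this assay, at which 1 of the 3 values shown sits.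

The compounds shown leave open whether any group on this nitrogen can bring the number below that of compound 1, as an unsubstituted phenyl, a pyridine ring, or a phenyl bearing an amine or a carboxylic acid might. They also cannot separate the kind of substituent from its place on the phenyl ring, as the three aryl groups differ in both.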